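This account rests on a few compounds, and the source may have more. Where it says the series, first, only, none or still open, it means among the compounds named here.

Compound 2 `CC1CCN(C2CCN(S(=O)(=O)c3ccc(-c4ccccc4F)cc3)CC2)CC1` gives the lowest number of the three measured compounds in a functional assay on DLD-1 cells (Homo sapiens) for antiproliferative activity, read by CellTiter-Glo, with a stated time of 72 h (on this read-out higher numbers stand for weaker inhibition and lower numbers for stronger inhibition), at 5 nM. Compound 3 `Cc1cc(C)c(S(=O)(=O)N2CCC(N3CC(C)CC(C)C3)CC2)c(C)c1` gives 17 nM in this assay, and compound 1 `Cc1cc(C)c(S(=O)(=O)N2CCC(N3CCC(c4ccccc4)CC3)CC2)c(C)c1` gives 865 nM, both gaps to compound 2 being beyond the scatter. Compound 4 `CCc1ccc(S(=O)(=O)N2CCC(N3CCC(C)CC3)CC2)cc1` has not yet been measured. It differs from compound 2 in one place: ethyl in place of 2-fluorophenyl on an aromatic carbon. Within the data shown here, no measured pair shows this same change, so its effect cannot be read off directly; the numbers for compound 1 and compound 3 only show that the aryl part matters. A loss of potency beyond the scatter is expected, a 12-fold higher number from compound 2 to compound 4 (1.08 log units; beyond the scatter). Compound 4 is therefore estimated to give 60 nM in this assay, with a likely range from 15 nM to 300 nM.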

Compound 4, half-maximal inhibitory concentration: > 5000 nM
Compound 4 gave a limit, no number (the forecaster's own chance of this, stated with the estimate: 3%); middle value at least 83-fold (1.92 log units) away from the limit.
By their numbers in this assay, from the lowest: compound 2; then compound 3; then compound 1. At a limit, above all of these: compound 4.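

Putting ethyl in place of 2-fluorophenyl on this aromatic carbon, para to a large group, gives an at least 1000-fold higher number from compound 2 to compound 4 (3.00 log units; beyond the scatter). For compound 4 this is a limit and not a number, so the full size of the step cannot be read: the limit of > 5000 nM in this assay, at which 1 of the 4 values shown sits. This one change shows that the activity of compound 2 in this assay depends on what sits at this position, and that ethyl does not replace 2-fluorophenyl there.

From the compounds shown here alone, what stays open is whether plain phenyl, a pyridyl ring or a longer chain at this position would keep that activity.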